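The source may hold more compounds than are shown below. What is called first, only, known or untested is meant among the compounds shown, and "the series" means these compounds.

The measured compounds:
Compound 1, `COc1cc(-c2ccnc3cc(-c4ccc(C)cc4)nn23)cc(OC)c1OC`, gives 3 nM in a functional assay on A549 cells (Homo sapiens) for inhibition, read by CCK-8 assay, with a stated time of 48 h; on this read-out higher numbers stand for weaker inhibition and lower numbers for stronger inhibition.
Compound 2, `COc1cc(-c2ccnc3cc(-c4ccc(C(C)(C)C)cc4)nn23)cc(OC)c1OC`, reaches only a limit of this assay, > 10000 nM.
Compound 3, `COc1cc(-c2ccnc3cc(-c4ccc5cnn(C)c5c4)nn23)cc(OC)c1OC`, gives 233 nM.

All three share one core and differ only in the aromatic group attached to it. Compound 3 stands highest of the two actual numbers; its nearest neighbour is compound 1, separated by a 78-fold higher number from compound 1 to compound 3 (1.89 log units; beyond the scatter). Compound 4, `COc1cc(-c2ccnc3cc(-c4ccc(F)cc4)nn23)cc(OC)c1OC`, has not been measured; compared with compound 3 the change is 4-fluorophenyl in place of 1-methyl-1H-indazol-6-yl on an aromatic carbon.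

Among the measured compounds shown here, two measured steps bear on it. Replacing 1-methyl-1H-indazol-6-yl by a six-membered ring of carbon only carrying methyl, seen as a 78-fold higher number from compound 1 to compound 3 (1.89 log units; beyond the scatter) read backwards, gave a much lower number, while enlarging that group to tert-butyl gave an at least 3300-fold higher number from compound 1 to compound 2 (3.52 log units; beyond the scatter), and the move from tert-butyl to the indazolyl gave an at least 42-fold lower number from compound 2 to compound 3 (1.63 log units; beyond the scatter). Compound 4 carries a single-ring group with one substituent, like compound 1, so a large downward step is expected, a 23-fold lower number from compound 3 to compound 4 (1.37 log units; beyond the scatter). Compound 4 is therefore estimated at 10 nM, in the range 2 nM to 60 nM.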

Compound 4, half-maximal inhibitory concentration: 3800 nM
For compound 4 the middle estimate is 380-fold (2.58 log units) below the measured one; the whole stated range lies below it.
By their numbers in this assay, from the lowest: compound 1; then compound 3; then compound 4. At a limit, above all of these: compound 2.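

In this assay, fluoro in place of methyl on the phenyl ring gives a 1300-fold higher number from compound 1 to compound 4 (3.10 log units; beyond the scatter), so a single-ring group with one substituent does not by itself bring a low number; here the substituent decides the outcome. Compound 4 also trails the two-ring indazolyl group, with a 16-fold higher number from compound 3 to compound 4 (1.21 log units; beyond the scatter), yet it still reads lower than the tert-butyl analogue, with an at least 2.6-fold lower number from compound 2 to compound 4 (0.42 log units; beyond the scatter). Compound 2 stands at a limit of the assay, so that last step is only a bound: the limit of > 10000 nM in this assay, at which 1 of the 4 values shown sits.

Among the three substituents on this phenyl ring, only methyl goes with a low number, and whether that holds more widely stays open. As far as these compounds go, how an ethyl, a methoxy, a chloro or an amine in the same place would read also remains unknown.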